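A few compounds are considered here, and "the series" means these few. Any claim that something is new, unique, unknown or untested is made for them only; others in the source may bear on it.

The measured compounds and their numbers in an assay on Sf9 cells for inhibition of protein deacetylase HDAC6 (Homo sapiens), read by fluorescence, with stated times of 90 min and 30 min; a higher number here means a weaker inhibitor, a lower number a stronger inhibitor:

Compound 1, `Cc1cc(C)cc(C(=O)N(CCC(=O)NCc2ccccc2)Cc2ccc(C(=O)NO)cc2)c1`: 20.5 nM
Compound 2, `O=C(CCN(Cc1ccc(C(=O)NO)cc1)C(=O)c1ccccc1)NCc1ccccc1`: 12.5 nM
Compound 3, `Cc1ccc(CNC(=O)CCN(Cc2ccc(C(=O)NO)cc2)C(=O)c2ccc(N(C)C)cc2)cc1`: 14.4 nM

Compound 2 gives the lowest of the three numbers, but its gap to compound 3 and its gap to compound 1 are both within the scatter, so none of the three can be called the stronger inhibitor. For the measured compounds named here, the one single-point step among them, a 1.6-fold lower number from compound 1 to compound 2 (0.21 log units; within the scatter), shows that removing two methyl groups from the aryl ring on the carbonyl carbon left the number essentially where it was.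

Compound 4, `COc1cc(OC)cc(C(=O)N(CCC(=O)NCc2ccccc2)Cc2ccc(C(=O)NO)cc2)c1`, is the next compound. It differs from compound 2 in one place: 3,5-dimethoxyphenyl in place of phenyl on a carbonyl carbon. Going by the values given here, the step that bears on this is the one from compound 1 to compound 2, in which a 3,5-disubstituted aryl on the same carbonyl carbon gave way to plain phenyl within the scatter; compound 3, with a differently substituted aryl on that carbonyl, also sits within the scatter of compound 2. Going back to a 3,5-disubstituted aryl is therefore expected to produce no step beyond the scatter, and the expected step is a 1.2-fold higher number from compound 2 to compound 4 (0.08 log units; within the scatter). Compound 4 is thus estimated to give 15 nM in this assay. Its range is estimated as 7 nM to 35 nM.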

Compound 4, half-maximal inhibitory concentration: 26 nM
Compound 4: the middle estimate sits 1.7-fold (0.24 log units) below what was measured; the range from low to high includes it.
By their numbers in this assay, from the lowest: compounds 2, 3, 1 and 4 (each within the scatter of the next, the first and the last beyond it).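

In this assay, for the compounds shown here, 3,5-dimethoxyphenyl on this carbonyl carbon gives the first single-place change at this position that clears the scatter, with a 2.1-fold higher number from compound 2 to compound 4 (0.32 log units; beyond the scatter), although the step is only modest. The two 3,5-disubstituted aryls do not separate from each other, since a 1.3-fold higher number from compound 1 to compound 4 (0.10 log units; within the scatter) stays within the scatter, so swapping the methyl groups for methoxy groups on the ring cannot be told apart here, and only 3,5-dimethoxyphenyl stands apart from plain phenyl. The position thus accepts this larger aryl with only a modest shift in the number, but nothing available here accounts for that shift.

The compounds shown leave open whether the shift comes from having two methoxy groups or would also appear with a single methoxy group, and what an amine or a carboxylic acid on this aryl would do at the same carbonyl carbon. They also leave open whether the step from phenyl to 3,5-dimethoxyphenyl would keep its size in a compound carrying the 4-methylbenzyl amide of compound 3.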